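This account rests on a few compounds, and the source may have more. Where it says the series, first, only, none or still open, it means among the compounds named here.

Compound 1, `CCS(=O)(=O)Nc1cc(C2CCCCC2)cc2c1CCCC2c1c[nH]cn1`, in an assay on isolated protein for binding affinity to Alpha-1A adrenergic receptor (Rattus norvegicus), read by radioligand binding (on this read-out higher numbers stand for weaker inhibition and lower numbers for stronger inhibition), gives 269 nM.
Compound 2, `CCCS(=O)(=O)Nc1cccc2c1CCCC2c1c[nH]cn1`, in this assay gives 1700 nM.

For the measured compounds named here, of these two, compound 2 has the higher number, and the gap to compound 1 lies beyond the usual scatter of repeated measurements; the two structures differ in more than one place, so no single step connects them. Compound 3, `O=S(=O)(Nc1cccc2c1CCCC2c1c[nH]cn1)C1CC1`, has not yet been measured. It differs from compound 2 in one place: cyclopropyl in place of propyl on a sulfonyl sulfur. Going by the values given here, both groups carry the same count of heavy atoms, all carbon, and neither adds a donor, an acceptor or a charge; the only change is that the chain is closed into a three-membered ring. Among the compounds with values here, with no measured pair showing what such a closure does, the expectation is a step of a 1.1-fold lower number from compound 2 to compound 3 (0.05 log units; within the scatter) that stays within the scatter. For compound 3 the estimate in this assay is therefore 1500 nM, with a range from 600 nM to 4000 nM.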

Compound 3, inhibition constant: 537 nM
Compound 3: middle estimate off by 2.8-fold (0.45 log units), on the high side; the measured number lies below the stated range.
By their numbers in this assay, from the lowest: compounds 1 and 3 (each within the scatter of the next); then compound 2.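

Closing the propyl chain into a cyclopropyl ring on a sulfonyl sulfur keeps the same count of carbons, yet in this assay it gives a 3.2-fold lower number from compound 2 to compound 3 (0.50 log units; beyond the scatter). At this place, then, the number depends on whether those carbons form a chain or a ring, even though no hydrogen-bond donor, acceptor or charge enters or leaves. Nothing measured here explains why the ring gives the lower number.

From the compounds shown here alone, this reading rests on a single pair, so it remains open whether the same closure would give a similar step on the core of compound 1. Also open, going by these compounds, is how a larger ring such as cyclobutyl, a longer chain such as butyl, or an amine on the sulfonyl sulfur would compare with cyclopropyl.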